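A Second Methoxy Group Added to Compound 1

The source may report more compounds than this note shows. Statements on the series, on what has been measured and on what is new or still open speak of the compounds shown alone.

Compound 1 `COc1ccc(-c2cc(/C=C/C(=O)c3ccc(N)cc3)[nH]n2)cc1`: 97%
Compound 2 `COc1ccc(C(=O)/C=C/c2cc(-c3cc(OC)c(OC)c(OC)c3)n[nH]2)cc1`: 87%
Compound 3 `COc1cc(-c2cc(/C=C/C(=O)c3ccc(F)c(F)c3)[nH]n2)cc(OC)c1OC`: 96%

In a functional assay on A498 cells (Homo sapiens) for cytotoxicity, read by sulforhodamine B assay, with a stated time of 48 h, tested at 0.1 uM (a higher number here means a weaker effect of the compound at the concentration tested, a lower number a stronger effect), compound 1 stands at the top of the three numbers, yet neither compound 3 nor compound 2 is separated from it by more than the usual scatter. Compound 4 `COc1ccc(-c2cc(/C=C/C(=O)c3ccc(N)cc3)[nH]n2)cc1OC` differs from compound 1 by methoxy in place of hydrogen on an aromatic carbon. For the measured compounds named here, the one measured step, a number 9 percentage points higher from compound 2 to compound 3 (within the scatter), exchanges the group on the carbonyl carbon and stays within the scatter; no measured step adds a methoxy group, so it bears only loosely on compound 4. With every number near the top of the scale, compound 4 is expected to give 95%, between 84% and 100%. The expected step of a number 2 percentage points lower from compound 1 to compound 4 (within the scatter) is therefore estimated to lie within the scatter.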

Compound 4, a percentage reported as activity, at one concentration (the size of the read-out at that concentration, not a potency): 80%
Estimate against measurement, compound 4: 15 percentage points above, outside the stated range (below it).
By their numbers in this assay, from the lowest: compounds 4, 2, 3 and 1 (each within the scatter of the next, the first and the last beyond it).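

In this assay, methoxy in place of hydrogen on this aromatic carbon, ortho to a methoxy group and meta to a large group, gives a number 17 percentage points lower from compound 1 to compound 4 (beyond the scatter). This is the first step among these compounds to lie beyond the scatter, and the lower number marks a stronger effect at the concentration tested, so this position responds to substitution. Nothing available explains the step.

As far as these compounds go, whether an ethoxy group, a hydroxyl group or a chlorine atom at the same carbon would give a similar step remains open.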